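A fourth aryl group on the shared core

The source may hold more compounds than are shown below. What is called first, only, known or untested is meant among the compounds shown, and "the series" means these compounds.

Compound 2 `COc1ccccc1N1CCN(CCCCC(=O)NCc2ccccc2-c2c(OC)cccc2OC)CC1` carries the 2,6-dimethoxyphenyl group and, in an assay on CHO-K1 cells for displacement of a labelled ligand from 5-hydroxytryptamine receptor 7 (Homo sapiens), read by scintillation counting (a higher number here means a weaker inhibitor, a lower number a stronger inhibitor), compound 2 gives 32.4 nM. Among the three measured compounds its number is the second highest, but every gap is small: compound 1 `COc1ccccc1N1CCN(CCCCC(=O)NCc2ccccc2-c2ccc(Cl)cc2)CC1` gives 25.9 nM in this assay, and compound 3 `COc1ccccc1N1CCN(CCCCC(=O)NCc2ccccc2-c2cccc(F)c2)CC1` gives 34.7 nM. The step of a 1.3-fold higher number from compound 1 to compound 2 (0.10 log units; within the scatter) and the step of a 1.1-fold higher number from compound 2 to compound 3 (0.03 log units; within the scatter) both stay within the scatter, as does a 1.3-fold higher number from compound 1 to compound 3 (0.13 log units; within the scatter), so the three aryl groups tried so far cannot be told apart on these numbers.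

Compound 4 `COc1ccccc1N1CCN(CCCCC(=O)NCc2ccccc2-c2ccc(C)cc2)CC1` has not yet been measured. It differs from compound 2 as follows: 4-methylphenyl in place of 2,6-dimethoxyphenyl on an aromatic carbon. Within the data shown here, the steps that bear on this change are those in which one aryl group was exchanged for another at the same place, a 1.3-fold higher number from compound 1 to compound 2 (0.10 log units; within the scatter) and a 1.1-fold higher number from compound 2 to compound 3 (0.03 log units; within the scatter), each within the scatter. Nothing in these data singles out 4-methylphenyl from the groups already tried, so no step beyond the scatter is expected in this assay in either direction. Compound 4 is therefore estimated to give 30 nM, with a range from 12 nM to 75 nM. That estimate means an expected step of a 1.1-fold lower number from compound 2 to compound 4 (0.03 log units; within the scatter), within the scatter.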

Compound 4, inhibition constant: 66.1 nM
Estimate against measurement, compound 4: 2.2-fold (0.34 log units) below, within the range that was stated.
By their numbers in this assay, from the lowest: compounds 1, 2, 3 and 4 (each within the scatter of the next, the first and the last beyond it).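

Among these compounds, the exchange at this aromatic carbon, ortho to a large group, yields the first steps in this assay that lie beyond the scatter: a 2.0-fold higher number from compound 2 to compound 4 (0.31 log units; beyond the scatter) and a 2.6-fold higher number from compound 1 to compound 4 (0.41 log units; beyond the scatter), both modest, so the aryl groups at this place can no longer all be treated as interchangeable. The second of these is the simple exchange of methyl for chloro on the otherwise unchanged aryl group, yet a 1.9-fold higher number from compound 3 to compound 4 (0.28 log units; within the scatter) keeps compound 4 inseparable from compound 3, so the separation holds only against compound 1 and compound 2 and does not set compound 4 apart from every other compound shown. No measurement available here accounts for these differences.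

The compounds shown leave open whether the modest step between methyl and chloro would extend to other groups on the same aryl ring, such as a 4-methoxyphenyl, a 4-trifluoromethylphenyl or a 4-aminophenyl group. They also leave open whether a carboxylic acid on that ring, or a longer chain joining the amide to the piperazine, would move the number further than any aryl exchange has so far.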